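Trimming One Methoxy Group from Compound 1

A few compounds are considered here, and "the series" means these few. Any claim that something is new, unique, unknown or untested is made for them only; others in the source may bear on it.

Of the compounds shown here, two sharing a common core have so far been measured in an assay on membranes from Cerebral cortex for displacement of a labelled ligand from Neuronal acetylcholine receptor; alpha4/beta2 (Rattus norvegicus); a lower number here means a stronger inhibitor, a higher number a weaker inhibitor. Compound 1 `COc1cc(NC(=O)c2cncc(N3CC4CC(C3)N4)c2)cc(OC)c1` carries two methoxy groups on its aromatic ring and gives 0.985 nM. Compound 2 `O=C(Nc1ccc(Cl)cc1)c1cncc(N2CC3CC(C2)N3)c1` carries a chloro group on that ring instead and gives 0.404 nM. Going by the values given here, of these two numbers, compound 1 stands at the higher one; its only neighbour, compound 2, sits at a lower number, and the gap between them lies beyond the usual scatter of this assay.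

Compound 3 `COc1cccc(NC(=O)c2cncc(N3CC4CC(C3)N4)c2)c1` has not yet been measured. It differs from compound 1 in a single place: hydrogen in place of methoxy on an aromatic carbon. The change is hydrogen in place of methoxy on an aromatic carbon of a six-membered aromatic ring of carbon only, meta to a large group and meta to a methoxy group, so one methoxy group remains.

Among the compounds with values here, no step between measured compounds matches this change, so there is nothing to copy directly. Both measured compounds reach low numbers despite quite different substituents on that ring, so the step of a 1.4-fold lower number from compound 1 to compound 3 (0.15 log units; within the scatter) is expected to be small, at most modestly toward a lower number and possibly within the scatter. Compound 3 is therefore estimated at 0.7 nM, with a likely range from 0.3 nM to 1.8 nM.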

Compound 3, inhibition constant: 0.56 nM
Beside the measured number, compound 3's estimate is 1.3-fold (0.10 log units) above it, and the stated range covers the measured number.
By their numbers in this assay, from the lowest: compounds 2, 3 and 1 (each within the scatter of the next, the first and the last beyond it).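

In this assay, hydrogen in place of methoxy on this aromatic carbon, meta to a large group and meta to a methoxy group, gives a 1.8-fold lower number from compound 1 to compound 3 (0.25 log units; within the scatter), so this assay does not separate the compound with one methoxy group from the one with two. With 3-methoxyphenyl in place of 4-chlorophenyl on the amide-type nitrogen, the result is a 1.4-fold higher number from compound 2 to compound 3 (0.14 log units; within the scatter), which places compound 3 within the scatter of both earlier compounds even though compound 1 and compound 2 lie beyond the scatter of each other. Nothing measured here offers an explanation for the size of either step.

Still open is whether the number would hold with hydrogen in place of the remaining methoxy group as well, since every compound shown keeps at least one substituent on this ring. Also open, on these data alone, is how an amine, a carboxylic acid or a longer chain such as butoxy would fare on this aromatic carbon, and so how widely this position tolerates change.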